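A few compounds are considered here, and "the series" means these few. Any claim that something is new, unique, unknown or untested is made for them only; others in the source may bear on it.

Measured so far:
- compound 1, `CN(CC1=CC[C@H]2C[C@@H]1C2(C)C)Cc1ccccc1I`: 5010 nM
- compound 2, `CN(CC1=CC[C@H]2C[C@@H]1C2(C)C)Cc1ccccc1`: 15800 nM

Of the compounds shown here, two have been tested in an assay on HEK293 cells for displacement of a labelled ligand from C-X-C chemokine receptor type 3 (Homo sapiens); a lower number here means a stronger inhibitor, a higher number a weaker inhibitor. Compound 1 gives 5010 nM. Among the measured compounds shown here, compound 2 gives 15800 nM, the highest of the two numbers; its only neighbour is compound 1, and the step of a 3.2-fold higher number from compound 1 to compound 2 (0.50 log units; beyond the scatter) is modest but beyond the scatter, with hydrogen in place of iodo on an aromatic carbon.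

Compound 3, `CN(CC1=CC[C@H]2C[C@@H]1C2(C)C)Cc1ccc(-c2ccccc2F)cc1`, has not yet been measured in this assay. It differs from compound 2 by 2-fluorophenyl in place of hydrogen on an aromatic carbon. For the measured compounds named here, no measured step covers a change of this kind; the only step known, a 3.2-fold higher number from compound 1 to compound 2 (0.50 log units; beyond the scatter), concerns the loss of a halogen at a different place on the same ring and shows that the bare phenyl of compound 2 gives the weaker number. On that slim basis, a larger substituent on this ring is expected to move the number down rather than up, by a step of a 3.2-fold lower number from compound 2 to compound 3 (0.50 log units; beyond the scatter) in this assay, though the size is uncertain. Compound 3 is estimated at 5000 nM, within 1000 nM to 25000 nM.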

Compound 3, inhibition constant: > 316 nM
Compound 3: a limit, no number (the forecaster's own chance of this, stated with the estimate: 15%); the middle value does not contradict the limit.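

In this assay compound 3 gives > 316 nM, which is a limit and not a number. The step from compound 2 to compound 3 therefore cannot be read: the limit of > 316 nM in this assay, at which 1 of the 3 values shown sits. The compounds shown leave open whether 2-fluorophenyl in place of hydrogen on this ring moves the number up or down, and by how much.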